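The compounds below may be only part of what the source reports. "The series", "measured", "known", "first", "only" and "open" are said of these compounds alone.

Compound 1 `COc1ccc2nc(C)cc(OCC(=O)Nc3cc(C)cc(C)c3)c2c1` is the point of departure. Within the data shown here, in a physicochemical assay for lipophilicity, read by HPLC, in phosphate buffer, measured as chromatographic lipophilicity, at pH 7.4 (on this read-out higher numbers stand for higher lipophilicity and lower numbers for lower lipophilicity), compound 1 gives 5.64, the lowest of the three numbers known; compound 2 `Cc1cc(C)cc(NC(=O)COc2cc(C)nc3ccc(C(F)(F)F)cc23)c1` gives 6.67 and compound 3 `COc1ccc2nc(C(F)(F)F)cc(OCC(=O)Nc3cc(C)cc(C)c3)c2c1` gives 7.02. Both known steps are large: a number 1.03 log units higher from compound 1 to compound 2 (beyond the scatter) and a number 1.38 log units higher from compound 1 to compound 3 (beyond the scatter). Compound 4 `COc1ccc2nc(C)cc(OC(C)C(=O)Nc3cc(C)cc(C)c3)c2c1` differs from compound 1 by methyl in place of hydrogen on a saturated chain carbon bound to a carbonyl carbon and an oxygen on an aromatic ring. Neither measured step bears directly on this change, as each replaces a group on an aromatic carbon with trifluoromethyl, whereas here a methyl enters on a saturated chain carbon. For this assay a modest rise beyond the scatter is expected, a number 0.36 log units higher from compound 1 to compound 4 (beyond the scatter). Compound 4 is therefore estimated at 6, within a range from 5.7 to 6.4.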

Compound 4, distribution coefficient: 5.76
Estimate against measurement, compound 4: 0.24 log units above; measured number inside the range.
By their numbers in this assay, from the lowest: compounds 1 and 4 (each within the scatter of the next); then compound 2; then compound 3.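

In this assay, methyl in place of hydrogen on this saturated chain carbon gives a number 0.12 log units higher from compound 1 to compound 4 (within the scatter). This is the first change shown at this chain carbon, and unlike the two large steps on aromatic carbons, its step cannot be told apart from the usual scatter. No measurement shown accounts for this result. The compounds shown leave open whether an ethyl group, a hydroxyl or an amine on this chain carbon would give a step beyond the scatter. They also leave open how methyl here would behave alongside trifluoromethyl on the aromatic carbon.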